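Methylating a Phenol on Two Stilbene Cores

This account rests on a few compounds, and the source may have more. Where it says the series, first, only, none or still open, it means among the compounds named here.

The study compares two pairs of compounds in a physicochemical assay for lipophilicity, read by HPLC; a lower number here means a more polar compound, a higher number a more lipophilic compound. Compound 2 `Oc1cc(/C=C/c2ccc(C(F)(F)F)cc2)ccc1/C=C/c1ccc(C(F)(F)F)cc1` bears a free hydroxy group on its core and gives 6.18 in this assay. Compound 1 `COc1cc(/C=C/c2ccc(C(F)(F)F)cc2)ccc1/C=C/c1ccc(C(F)(F)F)cc1` carries a methyl in place of hydrogen on an oxygen on an aromatic ring; the step of a number at least 0.82 log units higher from compound 2 to compound 1 (beyond the scatter) is therefore reported only as a lower bound. For compound 1 the assay returns > 7, which is a limit of the measurement rather than a number, and the limit of > 7 in this assay, at which 1 of the 3 values shown sits, marks where that limit lies. The structural change itself is methyl in place of hydrogen on an oxygen on an aromatic ring.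

Compound 3 `COc1ccc(/C=C/c2ccc(/C=C/c3ccc(OC)c(C(F)(F)F)c3)cc2O)cc1` rests on a different core; how that core differs from the core of compound 2 is not broken down here. In this assay compound 3 gives 7.17, which stands higher than the value of compound 2 by more than the usual scatter.

Compound 4 `COc1ccc(/C=C/c2ccc(/C=C/c3ccc(OC)c(C(F)(F)F)c3)cc2OC)cc1` is the yet unmeasured partner of compound 3, related to it by the same change, (methyl in place of hydrogen on an oxygen on an aromatic ring), on an oxygen on an aromatic ring whose other neighbours are aromatic carbon. Since compound 1 sits at a limit, the step from compound 2 to compound 1 gives only a floor, and the step of a number 0.83 log units higher from compound 3 to compound 4 (beyond the scatter) is expected to be of at least that size. On this basis compound 4 is estimated at 8 in this assay, with a range from 7.4 to 8.7, and a fair chance that the assay again returns only a limit.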

Compound 4, partition coefficient: > 7
Compound 4 gave a limit, no number; the forecaster's own chance of this, stated with the estimate: 40%; the middle value is on the limit's open side.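

In this assay, within the data shown here, compound 4 gives > 7, which is a limit of the assay and not a number, so no step from compound 3 to compound 4 can be read. The compounds shown leave open whether going from hydroxy to methoxy changes the value by the same amount on both cores, because compound 1 and compound 4 both stand at that limit: the limit of > 7 in this assay, at which 2 of the 4 values shown sit.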